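A few compounds are considered here, and "the series" means these few. Any claim that something is new, unique, unknown or untested is made for them only; others in the source may bear on it.

Measured compounds in an in vitro assay on 293-EBNA cells for binding affinity to corticotropin-releasing factor receptor 1 (Homo sapiens); on this read-out lower numbers stand for stronger inhibition and higher numbers for weaker inhibition:
compound 1 `CCN(CC)c1nc(C)nc2c1nnn2-c1ccc(C(C)C)cc1Br` — 25.3 nM
compound 2 `COCC(C)(C)Nc1nc(C)nc2c1nnn2-c1ccc(C(C)C)cc1Br` — 195 nM
compound 3 `COCCNc1nc(C)nc2c1ncn2-c1ccc(C(C)C)cc1Br` — 210 nM

Compound 2 holds the second highest of the three numbers. Compound 3 sits nearest to it, and the gap between compound 2 and compound 3 lies within the scatter of repeated measurements. Compound 1 sits furthest from compound 2, and that gap lies beyond the scatter.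

Compound 4 `CCC(COC)Oc1nc(C)nc2c1nnn2-c1ccc(C(C)C)cc1Br` has not yet been measured. The change from compound 2 to compound 4 is 1-(methoxymethyl)propoxy in place of (1-(methoxymethyl)-1-methylethyl)amino on an aromatic carbon.

Within the data shown here, only one measured step touches the same position: a 7.7-fold higher number from compound 1 to compound 2 (0.89 log units; beyond the scatter). That step exchanged one amino group for another and so gives no direct reading on an amino group giving way to an alkoxy group. Among the measured compounds shown here, no measured pair isolates the nitrogen-to-oxygen exchange on its own, and compound 3 differs from compound 2 in the core as well as in the chain, so it cannot anchor the step either. With nothing to pull the expectation strongly either way, a small step is expected, if anything toward a higher number. For compound 4 the expected value in this assay is 260 nM, with a range from 80 nM to 850 nM. This estimate means the step of a 1.3-fold higher number from compound 2 to compound 4 (0.12 log units; within the scatter) is expected to stay near the edge of the scatter.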

Compound 4, inhibition constant: 1.9 nM
Compound 4: middle estimate off by 140-fold (2.14 log units), on the high side, outside the stated range (below it).
By their numbers in this assay, from the lowest: compound 4; then compound 1; then compounds 2 and 3 (each within the scatter of the next).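

In this assay, a 100-fold lower number from compound 2 to compound 4 (2.01 log units; beyond the scatter) shows that this aromatic carbon responds strongly to replacing (1-(methoxymethyl)-1-methylethyl)amino with 1-(methoxymethyl)propoxy, even though both groups have 7 heavy atoms and 2 hydrogen-bond acceptors and only the first has a hydrogen-bond donor. Among these compounds, earlier, the only step at this position ran between two amino groups; now a 13-fold lower number from compound 1 to compound 4 (1.12 log units; beyond the scatter) places an oxygen-linked chain ahead of diethylamino as well, so among the compounds sharing this core, the lowest number no longer belongs to an amino group. No supporting measurement is available to explain the size of either step.

As far as these compounds go, the step from compound 2 to compound 4 changes both the linking atom and the branching of the chain, so the share of each remains open; 1-(methoxymethyl)propylamino on the same core, compared directly with compound 4, would separate them. Also open, from the compounds shown here alone, is whether a sulfur-linked 1-(methoxymethyl)propyl chain or a cyclopentyloxy group would keep a number this low, and whether 1-(methoxymethyl)propoxy gives a similar result on the core of compound 3.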